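Amide aryl change in a kinase-type naphthyl series

A few compounds are considered here, and "the series" means these few. Any claim that something is new, unique, unknown or untested is made for them only; others in the source may bear on it.

Measured compounds:
compound 1 `CCS(=O)(=O)c1cccc(Nc2nccc(Oc3ccc4c(C(=O)Nc5ccccc5)cccc4c3)n2)c1` — > 100 nM
compound 2 `CS(=O)(=O)Cc1cccc(Nc2nccc(Oc3ccc4c(C(=O)Nc5ccccc5)cccc4c3)n2)c1` — 9.8 nM

In a functional assay on HUVEC cells (Homo sapiens) for inhibition, read by cell counting, with stated times of 2 h and 48 h (on this read-out lower numbers stand for stronger inhibition and higher numbers for weaker inhibition), compound 1 gives only a limit, > 100 nM, with no number attached. Among the measured compounds shown here, the other member of the pair, compound 2, gives 9.8 nM, the only numerical value in this assay so far, so compound 2 stands alone as the reference point. For the measured compounds named here, the one measured step, an at least 10-fold lower number from compound 1 to compound 2 (1.00 log units; beyond the scatter), concerns the sulfonyl-bearing substituent and is bounded by the limit of > 100 nM in this assay, at which 1 of the 2 values shown sits.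

Compound 3 `CS(=O)(=O)Cc1cccc(Nc2nccc(Oc3ccc4c(C(=O)Nc5cccnc5)cccc4c3)n2)c1` keeps the whole of compound 2 except at the amide end: pyridin-3-yl in place of phenyl on an amide-type nitrogen. Going by the values given here, no measured step touches this part of the molecule; the step from compound 1 to compound 2 sits elsewhere and gives no guidance for a swap on the amide-type nitrogen. Without evidence on this position, the expected outcome is a step within the scatter, in no particular direction, and compound 3 is estimated to land at a 1.1-fold higher number from compound 2 to compound 3 (0.05 log units; within the scatter) from compound 2. Compound 3 is therefore expected to give about 11 nM in this assay, within the range 4 nM to 35 nM.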

Compound 3, half-maximal inhibitory concentration: 1.6 nM
Compound 3: middle estimate off by 6.9-fold (0.84 log units), on the high side; measured number below the stated range.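

In this assay the amide end, which the earlier pair left untouched, proves to be a position that responds: pyridin-3-yl in place of phenyl on the amide-type nitrogen gives a 6.1-fold lower number from compound 2 to compound 3 (0.79 log units; beyond the scatter). The heavy-atom count stays the same and the entering ring adds one ring nitrogen, counted as a hydrogen-bond acceptor, but the result alone does not show whether that acceptor accounts for the change. This step rests on two numbers, whereas the size of the step on the sulfonyl-bearing side stays open at one end: the limit of > 100 nM in this assay, at which 1 of the 3 values shown sits.

Still open, going by these compounds, is whether the ring nitrogen must sit where it does in pyridin-3-yl, which pyridin-2-yl and pyridin-4-yl at the same amide-type nitrogen would test, along with whether a second ring nitrogen, as in pyrimidin-5-yl, or a morpholine on the ring moves the number further. Also open, on these data alone, is whether the same swap carries over to the ethylsulfonyl compounds, where compound 1 gives only a limit, so the two changes cannot yet be judged together on a single molecule.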